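Swapping the piperidine substituent: compound 3 in rat distribution

The source may report more compounds than this note shows. Statements on the series, on what has been measured and on what is new or still open speak of the compounds shown alone.

Measured so far:
Compound 1, `CCCCCOC(=O)N1CCN(C(=O)[C@H](CCC(=O)O)NC(=O)c2cc(N3CCC(C(=O)N(CC)CC)CC3)nc(-c3ccccc3)n2)CC1`: 0.21 L/kg
Compound 2, `CCCCCOC(=O)N1CCN(C(=O)[C@H](CCC(=O)O)NC(=O)c2cc(N3CCC(OCCO)CC3)nc(-c3ccccc3)n2)CC1`: 0.8 L/kg

Both compounds were run in an in vivo ADME assay on the whole organism (strain Sprague-Dawley) for pharmacokinetics, with Rattus norvegicus as the target; a lower number here means that more of the compound stays in the plasma, a higher number that more of the compound sits outside the plasma. Within the data shown here, compound 1 gives 0.21 L/kg, while compound 2 gives 0.8 L/kg, the higher of the two numbers; the only step, a 3.8-fold higher number from compound 1 to compound 2 (0.58 log units; beyond the scatter), lies beyond the scatter. Compound 3, `CCCCCOC(=O)N1CCN(C(=O)[C@H](CCC(=O)O)NC(=O)c2cc(N3CCC(COC)CC3)nc(-c3ccccc3)n2)CC1`, has not yet been measured. It differs from compound 2 in one place: methoxymethyl in place of 2-hydroxyethoxy on a saturated ring carbon. The step from compound 1 to compound 2 is the only one that bears on this change, and it concerns the same saturated ring carbon, showing that a change of group there can move the number beyond the scatter. Among the measured compounds shown here, no measured step shows the exact exchange of 2-hydroxyethoxy for methoxymethyl, so the direction is not known. Compound 3 is therefore expected to stay close to compound 2, with a 1.3-fold lower number from compound 2 to compound 3 (0.12 log units; within the scatter), giving an estimated 0.6 L/kg, ranging from 0.25 L/kg to 1.4 L/kg.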

Compound 3, volume of distribution at steady state: 1.1 L/kg
For compound 3 the middle estimate is 1.8-fold (0.26 log units) below the measured one; the range from low to high includes it.
By their numbers in this assay, from the lowest: compound 1; then compounds 2 and 3 (each within the scatter of the next).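

In this assay the exchange of 2-hydroxyethoxy for methoxymethyl on this saturated ring carbon gives (a 1.4-fold higher number from compound 2 to compound 3 (0.14 log units; within the scatter)), so at this position a group with a hydrogen-bond donor and one without it read alike. Among these compounds, the exchange of diethylcarbamoyl for methoxymethyl gives (a 5.2-fold higher number from compound 1 to compound 3 (0.72 log units; beyond the scatter)), which leaves compound 1 apart from both compound 2 and compound 3, and so far diethylcarbamoyl is the only group here that sets a compound apart. Nothing measured here accounts for these numbers.

Going by these compounds, it remains open whether the low number of compound 1 belongs to diethylcarbamoyl alone or would also come with a smaller amide such as dimethylcarbamoyl. Also open, on these data alone, is how an amine, a carboxylic acid or a longer chain on this ring carbon would read.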